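Tert-butyl in place of methyl: expected to remain at the limit

A few compounds are considered here, and "the series" means these few. Any claim that something is new, unique, unknown or untested is made for them only; others in the source may bear on it.

Compound 1 `Cc1ccc(Cn2cc(COc3ccc4c(=O)ccoc4c3)nn2)cc1` is the reference point. In a functional assay on MDA-MB-231 cells (Homo sapiens) for cytotoxicity, read by MTT assay, with a stated time of 48 h (on this read-out lower numbers stand for stronger inhibition and higher numbers for weaker inhibition), compound 1 gives > 100000 nM, which is a limit of the assay and not a number. Compound 2 `O=c1ccoc2cc(OCc3cn(Cc4cccc(F)c4)nn3)ccc12` gives > 100000 nM in this assay, likewise a limit. Compound 3 `O=c1ccoc2cc(OCc3cn(Cc4ccc(Cl)cc4Cl)nn3)ccc12` gives > 100000 nM in this assay, also a limit. Where compound 1 stands is thus fixed only by the limit of > 100000 nM in this assay, at which 3 of the 3 values shown sit, and no ranking among the three is possible.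

The measured steps a step that the two limits leave unreadable from compound 1 to compound 2, a step that the two limits leave unreadable from compound 1 to compound 3 and a step that the two limits leave unreadable from compound 2 to compound 3 each exchange the group on a saturated chain carbon bound to an aromatic nitrogen, and their size cannot be read, since both ends sit at the limit. The step to compound 4 `CC(C)(C)c1ccc(Cn2cc(COc3ccc4c(=O)ccoc4c3)nn2)cc1` alters a different site: tert-butyl in place of methyl on an aromatic carbon. No measured step bears on this exchange with a readable size, so the size and direction of the step in this assay cannot be drawn from the shown data; what is known is that every variation so far remained at the limit (the limit of > 100000 nM in this assay, at which 3 of the 3 values shown sit).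

Compound 4 is therefore expected to give 150000 nM, within 60000 nM to 400000 nM. The expected step that the limit leaves unreadable from compound 1 to compound 4 is estimated as none beyond the scatter, most likely reported as a limit.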

Compound 4, half-maximal inhibitory concentration: > 100000 nM
Compound 4 gave a limit, no number; the forecaster's own chance of this, stated with the estimate: 85%; the middle value lies beyond the limit too.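

In this assay compound 4 gives > 100000 nM, which is a limit of the assay and not a number. No step from compound 1 to compound 4 can be read, as the series sits at a single limit: the limit of > 100000 nM in this assay, at which 4 of the 4 values shown sit.

The compounds shown leave open how far each lies beyond that limit and which structural change, if any, would give a measurable value in this assay.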